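The source may report more compounds than this note shows. Statements on the series, on what has been measured and on what is new or still open speak of the compounds shown alone.

Working notes on the series in a functional assay on the whole organism (strain Sprague-Dawley) for inhibition, with Rattus norvegicus as the target, with a stated time of 10 min; on this read-out lower numbers stand for an effect already at smaller amounts and higher numbers for an effect only at larger amounts of compound. Compound 1 `COc1ccccc1-c1ncc(C(=O)O)c(=O)[nH]1` gives 10 mg/kg. Compound 2 `CCOc1ccccc1-c1ncc(C(=O)O)c(=O)[nH]1` gives 0.5 mg/kg, with a 20-fold lower number from compound 1 to compound 2 (1.30 log units; beyond the scatter). Compound 3 `CCC(C)Oc1ccccc1-c1ncc(C(=O)O)c(=O)[nH]1` gives 0.5 mg/kg, with a 20-fold lower number from compound 1 to compound 3 (1.30 log units; beyond the scatter) and no change at the digits printed from compound 2 to compound 3 (within the scatter). Compound 2 therefore sits level with compound 3 at the digits printed, the two lowest numbers of the three, and far from compound 1.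

Compound 4 `CCOc1ccc(S(=O)(=O)N(C)C(C)C)cc1-c1ncc(C(=O)O)c(=O)[nH]1` differs from compound 2 by isopropyl(methyl)sulfamoyl in place of hydrogen on an aromatic carbon. Among the measured compounds shown here, no measured step touches this kind of change: all three steps vary only the alkoxy group, and the ethoxy group of compound 2 is kept in compound 4. No direction can be read from them, so the working expectation is a step of a 1.4-fold higher number from compound 2 to compound 4 (0.15 log units; within the scatter) in this assay, not beyond the scatter. Compound 4 is thus estimated at 0.7 mg/kg, within 0.15 mg/kg to 3 mg/kg.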

Compound 4, dose for 50% inhibition: > 10 mg/kg
Compound 4: only a limit was reported (the forecaster's own chance of this, stated with the estimate: 5%); at least 14-fold (1.15 log units) between middle value and limit.
By their numbers in this assay, from the lowest: compounds 2 and 3 (each within the scatter of the next); then compound 1.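

In this assay, among the compounds shown here, the aromatic carbon para to an ethoxy group proves sensitive to substitution, which the earlier compounds, varying only the alkoxy group, could not show: isopropyl(methyl)sulfamoyl in place of hydrogen there gives an at least 20-fold higher number from compound 2 to compound 4 (1.30 log units; beyond the scatter). Keeping the ethoxy group therefore does not by itself keep the low number. Compound 4 stands only as a limit, not a number, so the full size of the step stays unknown: the limit of > 10 mg/kg in this assay, at which 1 of the 4 values shown sits.

On these data alone, whether the rise belongs to the whole sulfamoyl group or to its isopropyl and methyl substituents stays open. So does the outcome for a smaller group at this carbon, such as an amine or a fluorine atom.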